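This account rests on a few compounds, and the source may have more. Where it says the series, first, only, none or still open, it means among the compounds named here.

Measured compounds:
compound 1, `O=C(O)CCc1ccc(C#Cc2ccnc(F)c2)cc1`, 98%
compound 2, `O=C(O)CCc1ccc(C#Cc2ccncc2)cc1`, 100%

In an in vitro functional assay on 1321-N1 cells for agonist activity at Free fatty acid receptor 1 (Homo sapiens), read by fluorescence, spectrophotometry and calcium flux (a lower number here means a smaller maximal response, a higher number a larger maximal response), compound 2 sits level with compound 1: the step of a number 2 percentage points higher from compound 1 to compound 2 (within the scatter) lies within the scatter, so neither compound can be set above the other. Compound 3 `O=C(O)CCc1ccc(C#Cc2ccnc(Oc3ccccc3)c2)cc1` carries the change (phenoxy in place of hydrogen on an aromatic carbon). Within the data shown here, no measured step introduces a phenoxy group; the single step available concerns hydrogen in place of fluoro and was within the scatter, so it bears on compound 3 only loosely. Both measured maximal responses stand at full level. Compound 3 is expected to stay near that level or drop somewhat, step a number 10 percentage points lower from compound 2 to compound 3 (within the scatter), estimate 90% with range 60% to 105%.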

Compound 3, largest response reached (reported as efficacy), in percent of the reference or control that the assay uses: 94%
Estimate against measurement, compound 3: 4 percentage points below; low and high end bracket the measured number.
By their numbers in this assay, from the lowest: compounds 3, 1 and 2 (each within the scatter of the next).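

In this assay, the position next to the ring nitrogen accommodates phenoxy, with its 7 heavy atoms and aromatic ring, in place of hydrogen: the record shows a number 6 percentage points lower from compound 2 to compound 3 (within the scatter) and the maximal response stays level. Against fluoro at the same position, the record shows a number 4 percentage points lower from compound 1 to compound 3 (within the scatter) and again no separation, so hydrogen, fluoro and phenoxy cannot be ranked here. No evidence at hand accounts for this. Still open, going by these compounds, is whether an amine, a carboxylic acid or a longer chain at this position would keep the response level in this assay.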